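A stability limit and the step to compound 3

The compounds below may be only part of what the source reports. "The series", "measured", "known", "first", "only" and "open" are said of these compounds alone.

In an ADME assay on a cell-free system (plasma, Homo sapiens) for metabolic stability (on this read-out lower numbers stand for a shorter-lived compound and higher numbers for a longer-lived compound), compound 1 `CCNc1[nH]c(=O)n(O)c(=O)c1C(=O)NCc1ccccc1` gives > 24 h, which is a limit of the assay and not a number. Compound 2 `CCNc1[nH]c(=O)n(O)c(=O)c1C(=O)NCc1ccc(F)cc1` gives > 24 h, which is also a limit and not a number, so its true position is not known. For the measured compounds named here, the one measured change, fluoro in place of hydrogen on an aromatic carbon, is a step that the two limits leave unreadable from compound 1 to compound 2. Compound 3 `CCNc1[nH]c(=O)n(O)c(=O)c1C(=O)NCc1ccc(C)c(F)c1` differs from compound 2 by 3-fluoro-4-methylphenyl in place of 4-fluorophenyl on a saturated chain carbon bound to an amide-type nitrogen. Going by the values given here, the earlier step also touched the aromatic ring, so it is the only guide, but it offers no size to carry over. No step beyond the scatter is therefore expected in this assay, and no direction can be named. Because of the limit of > 24 h in this assay, at which 2 of the 2 values shown sit, another reading at the limit is the likeliest outcome for compound 3. The estimated step is a step that the limit leaves unreadable from compound 2 to compound 3. Compound 3 is expected at 30 h, with an estimated range from 15 h to 60 h.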

Compound 3, half-life in the Homo sapiens assay: > 24 h
Compound 3: a limit, no number; the forecaster's own chance of this, stated with the estimate: 85%; the middle value lies beyond the limit too.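

In the Homo sapiens assay compound 3 gives > 24 h, which is a limit of the assay and not a number. No step among compound 1, compound 2 and compound 3 can be read because all three sit at this limit: the limit of > 24 h in the Homo sapiens assay, at which 3 of the 3 values shown sit.

From the compounds shown here alone, how long these three compounds truly last in the Homo sapiens assay, and whether the changes on the aromatic ring alter that at all, stays open.

In a physicochemical assay for solubility (on this read-out higher numbers stand for higher solubility and lower numbers for lower solubility), compound 2 gives 150000 nM and compound 3 gives 81000 nM. In the physicochemical assay the change of 4-fluorophenyl to 3-fluoro-4-methylphenyl is a 1.9-fold lower number from compound 2 to compound 3 (0.27 log units; within the scatter).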